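This account rests on a few compounds, and the source may have more. Where it says the series, first, only, none or still open, it means among the compounds named here.

Compound 1 `Nc1n[nH]c2cccc(-c3cccc(NC(=O)Nc4ccc(Cl)cc4Cl)c3)c12` was tested in a functional assay on A549 cells (Homo sapiens) for inhibition, read by MTT assay, with a stated time of 48 h; a higher number here means a weaker inhibitor, a lower number a stronger inhibitor. For compound 1 the result is a limit of the assay rather than a number, > 500000 nM; in other words, (the limit of > 500000 nM in this assay, at which 1 of the 3 values shown sits). Compound 2 `Cc1ccc(NC(=O)Nc2cccc(-c3cccc4[nH]nc(N)c34)c2)cc1Cl` gives 1750 nM in this assay, and compound 3 `Nc1n[nH]c2cccc(-c3cccc(NC(=O)Nc4cccc(C(F)(F)F)c4)c3)c12` gives 1950 nM. Each differs from compound 1 in one place only, and both steps are large: an at least 280-fold lower number from compound 1 to compound 2 (2.45 log units; beyond the scatter) and an at least 250-fold lower number from compound 1 to compound 3 (2.40 log units; beyond the scatter). Compound 4 `Nc1n[nH]c2cccc(-c3cccc(NC(=O)Nc4nccs4)c3)c12` has not yet been measured; it differs from compound 1 at the same place: 1,3-thiazol-2-yl in place of 2,4-dichlorophenyl on an amide-type nitrogen. Both measured changes at that place gave large drops from compound 1, so a large downward step is expected here too, although the entering ring is of a different kind. Compound 4 is expected to give 5000 nM in this assay, within 800 nM to 100000 nM. The expected step is then an at least 100-fold lower number from compound 1 to compound 4 (2.00 log units; beyond the scatter).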

Compound 4, half-maximal inhibitory concentration: > 500000 nM
Compound 4: only a limit was reported (the forecaster's own chance of this, stated with the estimate: 20%); middle value at least 100-fold (2.00 log units) away from the limit.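

At this amide-type nitrogen, the ring cannot be exchanged freely: 1,3-thiazol-2-yl in place of the substituted phenyl rings gives an at least 280-fold higher number from compound 2 to compound 4 (2.45 log units; beyond the scatter) and an at least 250-fold higher number from compound 3 to compound 4 (2.40 log units; beyond the scatter). Compound 4 has a limit of the assay rather than a number, and it is the same limit as for compound 1: the limit of > 500000 nM in this assay, at which 2 of the 4 values shown sit. The step between these two limits cannot be read.

From the compounds shown here alone, what remains open is whether the loss follows from the smaller ring or from its hetero atoms. An unsubstituted phenyl or a pyridine ring at the same place would bear on that question.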